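Adding Bromine to Compound 2: What to Expect

The compounds below may be only part of what the source reports. "The series", "measured", "known", "first", "only" and "open" are said of these compounds alone.

Measured so far:
compound 1, `CNc1nc(O)c(Br)c(-c2ccccc2)n1`: 78%
compound 2, `Cn1c(-c2ccccc2)cc(=O)[nH]c1=O`: 47%
compound 3, `Nc1nc(O)c(I)c(-c2ccccc2)n1`: 3%

Of the compounds shown here, three have been measured in a functional assay on the whole organism for inhibition, with Rattus norvegicus as the target, at a dose of 50 mg/kg by the oral route; a higher number here means a stronger effect of the compound at the dose given, a lower number a weaker effect. Compound 2 stands second highest of the three: compound 1 lies above it by a margin beyond the scatter, and compound 3 lies below it, again beyond the scatter. Compound 4, `Cn1c(-c2ccccc2)c(Br)c(=O)[nH]c1=O`, has not yet been measured. It differs from compound 2 in one place: bromo in place of hydrogen on an aromatic carbon.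

Going by the values given here, no pair of measured compounds differs in exactly this single way, so the size of this step cannot be read off from a known pair. Among the compounds with values here, compound 1 also carries bromo on its core and gives 78%, the highest value so far. Compound 3 carries iodo on its core and gives 3%, the lowest. These two values pull in opposite directions, and neither shares the core of compound 2, so the guide is weak. Leaning on the value of compound 1, which shares the bromo group, a moderate rise is expected: a number 13 percentage points higher from compound 2 to compound 4 (beyond the scatter). For compound 4 the estimated result in this assay is 60%, with a range from 30% to 85%.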

Compound 4, a percentage reported as inhibition, in the whole organism at one dose (the size of the read-out at that dose, not a potency): 43%
Beside the measured number, compound 4's estimate is 17 percentage points above it; the range from low to high includes it.
By their numbers in this assay, from the lowest: compound 3; then compounds 4 and 2 (each within the scatter of the next); then compound 1.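

In this assay, bromo in place of hydrogen on this aromatic carbon, ortho to a group of 6 heavy atoms and two atoms from the ring nitrogen, gives a number 4 percentage points lower from compound 2 to compound 4 (within the scatter), so at this dose the two compounds cannot be told apart. Going by these compounds alone, this is the first one-place comparison for this change, and it shows that this position can carry a bromo group without a readable gain or loss in the effect; the earlier halogen-bearing compounds sit on other cores and could not show this. Nothing available explains why the step is so small.

The compounds shown leave open whether this carbon is insensitive to change in general or only to this swap, since an amine, a carboxylic acid or a longer chain at the same place could still move the number beyond the scatter. A read-out at one dose also leaves open whether compound 2 and compound 4 would stay level at other doses, as it gives the size of the effect at that dose and not a potency.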